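A few compounds are considered here, and "the series" means these few. Any claim that something is new, unique, unknown or untested is made for them only; others in the source may bear on it.

Three compounds that share one core have numbers in an ADME assay on microsomes from liver (Homo sapiens) for metabolic stability, read by LC-MS, with a stated time of 30 min, tested at 1 uM; a lower number here means that less of the compound is left, a higher number that more of the compound is left. Compound 1 `O=C(NCc1ccc(S(=O)(=O)c2ccccc2C(F)(F)F)cc1)c1cc2cnccc2[nH]1`, with 2-(trifluoromethyl)phenyl on the sulfonyl sulfur, gives 52%. Compound 2 `O=C(NCc1ccc(S(=O)(=O)c2ccccc2)cc1)c1cc2cnccc2[nH]1`, with phenyl there, gives 75%. Compound 3 `O=C(NCc1ccc(S(=O)(=O)c2ccc(F)c(F)c2)cc1)c1cc2cnccc2[nH]1`, with 3,4-difluorophenyl, gives 100%, the highest of the three numbers.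

Compound 4 `Cc1cccc(S(=O)(=O)c2ccc(CNC(=O)c3cc4cnccc4[nH]3)cc2)c1` keeps the shared core and differs from compound 3 only in the group on the sulfonyl sulfur: 3-methylphenyl in place of 3,4-difluorophenyl on a sulfonyl sulfur. In words, 3-methylphenyl takes the place of 3,4-difluorophenyl. Among the compounds with values here, no measured compound carries 3-methylphenyl, so the guidance is indirect.

The closest measured change is the one between phenyl and 3,4-difluorophenyl, a number 25 percentage points higher from compound 2 to compound 3 (beyond the scatter). The change between the two substituted groups is larger, a number 48 percentage points higher from compound 1 to compound 3 (beyond the scatter), while removing the trifluoromethyl gives a number 23 percentage points higher from compound 1 to compound 2 (beyond the scatter). Both groups measured in place of 3,4-difluorophenyl thus gave lower numbers, so a fall is expected on leaving it, probably close in size to the modest steps. The estimated change is a number 28 percentage points lower from compound 3 to compound 4 (beyond the scatter). For compound 4 the expected value in this assay is 72%, with an estimated range from 52% to 90%.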

Compound 4, percent of the compound remaining: 49%
Beside the measured number, compound 4's estimate is 23 percentage points above it, outside the stated range (below it).
By their numbers in this assay, from the lowest: compounds 4 and 1 (each within the scatter of the next); then compound 2; then compound 3.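

On the sulfonyl sulfur, the 3-methylphenyl group gives up the whole advantage of 3,4-difluorophenyl in this assay (a number 51 percentage points lower from compound 3 to compound 4 (beyond the scatter)), and it also falls short of the unsubstituted phenyl (a number 26 percentage points lower from compound 2 to compound 4 (beyond the scatter)). Compound 3 had suggested that a substituted phenyl could improve on plain phenyl, but among the three substituted groups now shown it is the only one that does, with compound 1 and compound 4 both lying under compound 2; the swap between their two groups makes no difference that can be told apart (a number 3 percentage points lower from compound 1 to compound 4 (within the scatter)). Nothing shown here gives a cause for the lower number of compound 4. The compounds shown leave open whether the gain in compound 3 needs both fluorines or would survive with one, as in 3-fluorophenyl or 4-fluorophenyl. They also leave open how groups such as 3-chlorophenyl, 3-methoxyphenyl or 4-methylphenyl would behave in this assay on this sulfonyl sulfur.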